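A few compounds are considered here, and "the series" means these few. Any claim that something is new, unique, unknown or untested is made for them only; others in the source may bear on it.

Of the compounds shown here, two have been measured in a functional assay on SK-MEL-28 cells (Homo sapiens) for cytotoxicity, read by MTT assay; on this read-out lower numbers stand for stronger inhibition and higher numbers for weaker inhibition. Compound 1 `O=S(=O)(NCCNc1nccc(-c2c(-c3cccc(F)c3)nc3sccn23)n1)c1ccc(Br)cc1` gives 13500 nM, and compound 2 `O=S(=O)(NCCNc1nccc(-c2c(-c3cccc(F)c3)nc3sccn23)n1)c1ccc(F)cc1` gives 9450 nM. The two stand within the scatter of each other, the step being a 1.4-fold lower number from compound 1 to compound 2 (0.15 log units; within the scatter). Compound 3 `O=S(=O)(NCCCNc1nccc(-c2c(-c3cccc(F)c3)nc3sccn23)n1)c1ccc(Cl)cc1` carries (((4-chlorophenyl)sulfonyl)amino)methyl in place of ((4-fluorophenyl)sulfonyl)amino on a saturated chain carbon, two bonds along the chain from a nitrogen on an aromatic ring. For the measured compounds named here, the only measured step that bears on this change is the halogen swap, which stayed within the scatter; for the longer chain no measured pair exists. In this assay no step beyond the scatter is therefore expected, a 1.0-fold higher number from compound 2 to compound 3 (0.00 log units; within the scatter). Compound 3 is estimated at 9500 nM, with a range from 3000 nM to 30000 nM.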

Compound 3, half-maximal inhibitory concentration: 8450 nM
For compound 3 the middle estimate is 1.1-fold (0.05 log units) above the measured one; the range from low to high includes it.
By their numbers in this assay, from the lowest: compounds 3, 2 and 1 (each within the scatter of the next).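

Lengthening the chain by a methyl while chlorine replaces the other halogen leaves the number in this assay within the scatter, whether compared with the fluoro compound (a 1.1-fold lower number from compound 2 to compound 3 (0.05 log units; within the scatter)) or the bromo compound (a 1.6-fold lower number from compound 1 to compound 3 (0.20 log units; within the scatter)). This position therefore accepts (((4-chlorophenyl)sulfonyl)amino)methyl without a readable step, though the added methyl and the chlorine change together and cannot be separated here. No measurement at hand bears on the reason for this flat result. As far as these compounds go, whether a still longer chain, an amine or a carboxylic acid in this place would give a step beyond the scatter remains open.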